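The source may report more compounds than this note shows. Statements on the series, on what has been measured and on what is new or still open speak of the compounds shown alone.

Within the data shown here, compound 3 `Cn1c(COc2cccc(C(=O)O)c2)nc2ccc(Oc3ccccn3)cc21` gives 62 ug/mL in a physicochemical assay for solubility, read by HPLC, measured as thermodynamic solubility, with a stated time of 4 h, at pH 6.8 (a higher number here means a more soluble compound, a lower number a less soluble compound), the highest of the three numbers so far, although compound 1 `Cc1ccc(Oc2ccc3nc(COc4cccc(C(=O)O)c4)n(C)c3n2)cc1`, which gives 33 ug/mL, lies within the scatter of it, so no order between those two is claimed. Compound 2 `Cc1cc(C)cc(Oc2ccc3nc(COc4cccc(C(=O)O)c4)n(C)c3n2)c1` gives 0.5 ug/mL in this assay and stands well below both. Compound 4 `Cc1cc(Cl)cnc1Oc1ccc2nc(COc3cccc(C(=O)O)c3)n(C)c2c1` is not yet measured; it differs from compound 3 by 5-chloro-3-methylpyridin-2-yl in place of pyridin-2-yl on an oxygen on an aromatic ring. Among the measured compounds shown here, one measured step bears on a change of this kind: a 66-fold lower number from compound 1 to compound 2 (1.82 log units; beyond the scatter), where 3,5-dimethylphenyl in place of 4-methylphenyl on the same oxygen brought a large drop. The change from compound 3 to compound 4 likewise adds substituents, here both chloro and methyl, to the ring carried by that oxygen, so a drop beyond the scatter is expected, with the reference step read as an upper bound on its size since it is the only one available. Compound 4 is expected to give about 3 ug/mL, within 0.5 ug/mL to 15 ug/mL, corresponding to an expected step of a 21-fold lower number from compound 3 to compound 4 (1.32 log units; beyond the scatter).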

Compound 4, solubility: 3.9 ug/mL
Estimate against measurement, compound 4: 1.3-fold (0.11 log units) below, within the range that was stated.
By their numbers in this assay, from the lowest: compound 2; then compound 4; then compounds 1 and 3 (each within the scatter of the next).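

In this assay, 5-chloro-3-methylpyridin-2-yl in place of pyridin-2-yl gives a 16-fold lower number from compound 3 to compound 4 (1.20 log units; beyond the scatter) on the core of compound 3, so a large step at this place is not confined to the phenyl groups on the core of compound 1. Read with a 66-fold lower number from compound 1 to compound 2 (1.82 log units; beyond the scatter), both steps that put a larger group on this oxygen run downward; no compound shown goes against this, but only these two pairs carry it. Nothing shown gives a cause for either step.

Chloro and methyl enter together, so the share of each in the step stays unresolved, as do 5-chloropyridin-2-yl and 3-methylpyridin-2-yl alone. Also open, on these data alone, is how an amine or a hydroxyl group on this ring would read in this assay on either core.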